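A few compounds are considered here, and "the series" means these few. Any claim that something is new, unique, unknown or untested is made for them only; others in the source may bear on it.

Going by the values given here, compound 2 `COc1ccc(C(=O)/C=C/c2cc(-c3cc(OC)c(OC)c(OC)c3)n[nH]2)cc1OC` gives -88% in a functional assay on PC-3 cells (Homo sapiens) for cytotoxicity, read by sulforhodamine B assay, with a stated time of 48 h, tested at 10 uM (a lower number here means a stronger effect, a higher number a weaker effect of the compound at the concentration tested), the lowest of the two numbers measured so far. Among the compounds with values here, its nearest neighbour is compound 1 `COc1cc(-c2cc(/C=C/C(=O)c3ccc(Cl)c(Cl)c3)[nH]n2)cc(OC)c1OC`, which in this assay gives 39%; the single measured step, a number 127 percentage points lower from compound 1 to compound 2 (beyond the scatter), arises from placing 3,4-dimethoxyphenyl in place of 3,4-dichlorophenyl on a carbonyl carbon. Compound 3 `COc1cc(C(=O)/C=C/c2cc(-c3cc(OC)c(OC)c(OC)c3)n[nH]2)cc(OC)c1OC` differs from compound 2 by methoxy in place of hydrogen on an aromatic carbon, the addition falling on an aromatic carbon of a six-membered aromatic ring of carbon only. Within the data shown here, no measured step touches this kind of change: the one known step swaps whole aryl groups, not a single methoxy, so it offers no guide to size or direction. The expectation for compound 3 is therefore a step of a number 13 percentage points higher from compound 2 to compound 3 (beyond the scatter), within the scatter, and compound 3 is estimated to give -75% in this assay, between -115% and 5%.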

Compound 3, a percentage reported as activity, at one concentration (the size of the read-out at that concentration, not a potency): -69%
The estimate for compound 3 lay 6 percentage points below the measured number; the measured number falls inside the stated range.
By their numbers in this assay, from the lowest: compound 2; then compound 3; then compound 1.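

In this assay, adding one methoxy on an aromatic carbon, ortho to a methoxy group and meta to a large group, gives a number 19 percentage points higher from compound 2 to compound 3 (beyond the scatter), which means a weaker effect at the concentration tested. Going by these compounds alone, the earlier step swapped whole aryl groups, so this is the first reading of a single methoxy on its own, and it shows that this position is sensitive to the change, though only modestly, since compound 3 still gives -69%. Nothing at hand accounts for the size or direction of this step.

The compounds shown leave open whether a hydroxyl, an amine or a longer alkoxy chain on this same carbon would shift the number in the same direction. They also leave open whether a smaller atom such as fluorine there would leave it unchanged.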